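The compounds below may be only part of what the source reports. "The series", "measured", "known", "first", "only" and "open" are said of these compounds alone.

Three compounds built on one shared core were tested in a functional assay on cells (blood, Homo sapiens) for inhibition, read by chemiluminescence, with a stated time of 30 min; a lower number here means a stronger inhibitor, a higher number a weaker inhibitor. Compound 1 has the structure `CC1(C)CC(=O)C(C(=S)SCc2ccccc2)=C(Nc2ccc(Cl)cc2Cl)C1`. In this assay compound 1 reaches only the limit of the measurement, > 100 ug/mL, and no number. Compound 2, `CC1(C)CC(=O)C(C(=S)SCCO)=C(Nc2ccc(Cl)cc2Cl)C1`, differs from compound 1 in one place: hydroxymethyl in place of phenyl on a saturated chain carbon bound to a sulfur. For compound 2 this assay likewise gives only a limit, > 100 ug/mL. Compound 3, `CC1(C)CC(=O)C(C(=S)SCc2ccccc2)=C(Nc2ccc(Cl)cc2)C1`, differs from compound 1 in another place: hydrogen in place of chloro on an aromatic carbon. For compound 3 too this assay reports a limit, > 100 ug/mL. Neither a step that the two limits leave unreadable from compound 1 to compound 2 nor a step that the two limits leave unreadable from compound 1 to compound 3 has a readable size: at both ends of each step stands a limit. What the three values do show is the limit of > 100 ug/mL in this assay, at which 3 of the 3 values shown sit.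

Compound 4, not yet measured, has the structure `CC1(C)CC(=O)C(C(=S)SCCO)=C(Nc2ccc(Cl)cc2)C1`. It stands to compound 3 as compound 2 stands to compound 1: hydroxymethyl in place of phenyl on a saturated chain carbon bound to a sulfur. The place of this change is described in the same words in both pairs, so it is the same change made on a different core, and how the two cores differ has already been told above. The step from compound 3 to compound 4 is expected to be a step that the limit leaves unreadable from compound 3 to compound 4, set beside a step that the two limits leave unreadable from compound 1 to compound 2, and this expectation rests on (the limit of > 100 ug/mL in this assay, at which 3 of the 3 values shown sit), where the earlier change of this kind led from one limit to another. Compound 4 is therefore estimated to give 200 ug/mL in this assay, with an expected range from 100 ug/mL to 1000 ug/mL, most likely again only a limit.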

Compound 4, half-maximal inhibitory concentration: > 100 ug/mL
Compound 4: only a limit was reported (the forecaster's own chance of this, stated with the estimate: 85%); the middle value does not contradict the limit.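

Compound 4 gives only a limit in this assay, > 100 ug/mL, and not a number, so neither its step from compound 3 nor its step from compound 2 can be read. The compounds shown leave open whether hydroxymethyl in place of phenyl, or hydrogen in place of chloro, changes inhibition at all, since every result so far is the same limit: the limit of > 100 ug/mL in this assay, at which 4 of the 4 values shown sit.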